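Methoxy to hydroxy on the methylphenyl arm

The compounds below may be only part of what the source reports. "The series", "measured", "known", "first", "only" and "open" are said of these compounds alone.

In a functional assay on HCT-15 cells (Homo sapiens) for inhibition, read by sulforhodamine B assay, with a stated time of 48 h (a lower number here means a stronger inhibitor of growth, a higher number a weaker inhibitor of growth), compound 1 `COc1cc(C)cc(-c2nn(CC#N)cc2-c2ccc(-c3cccc(C(C)=O)c3)nc2)c1` gives only a limit, > 100000 nM. Compound 2 `Cc1cc(O)cc(-c2nn(CC#N)cc2-c2ccnc(-c3ccc(Oc4ccccc4)cc3)c2)c1` gives 5380 nM. Compound 3 `COc1cc(C)cc(-c2nn(CC#N)cc2-c2ccnc(-c3ccc(N(C)C)cc3)c2)c1` gives 8790 nM, the higher of the two numbers recorded, though its gap to compound 2 lies within the scatter, so no ranking between them is claimed. Compound 1 stands apart as a limit (the limit of > 100000 nM in this assay, at which 1 of the 3 values shown sits). Compound 4 `Cc1cc(O)cc(-c2nn(CC#N)cc2-c2ccnc(-c3ccc(N(C)C)cc3)c2)c1` is not yet measured; it differs from compound 3 by hydrogen in place of methyl on an oxygen on an aromatic ring, that is methoxy to hydroxy, 3-methoxy-5-methylphenyl to 3-hydroxy-5-methylphenyl. For the measured compounds named here, no measured pair isolates this change; compound 2 carries the hydroxy but differs elsewhere too, so its value and that of compound 3 show only that both are numbers rather than limits. The expected step, a 1.4-fold lower number from compound 3 to compound 4 (0.13 log units; within the scatter), is small, with no direction beyond the scatter. Compound 4 is estimated at 6500 nM in this assay, within 2500 nM to 17000 nM.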

Compound 4, concentration for total growth inhibition: 18200 nM
Compound 4: middle estimate off by 2.8-fold (0.45 log units), on the low side; measured number above the stated range.
By their numbers in this assay, from the lowest: compounds 2 and 3 (each within the scatter of the next); then compound 4. At a limit, above all of these: compound 1.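

In this assay, this pair isolates methoxy to hydroxy on the 3-methoxy-5-methylphenyl arm, and the change gives a 2.1-fold higher number from compound 3 to compound 4 (0.32 log units; beyond the scatter), so at this position the hydroxy does not match the methoxy with the dimethylamino group held constant. With the hydroxy held constant, dimethylamino in place of phenoxy gives a 3.4-fold higher number from compound 2 to compound 4 (0.53 log units; beyond the scatter), so the other arm also moves the number. Nothing shown bears on the cause of either step. Still open, going by these compounds, is whether the methoxy to hydroxy step carries over to the phenoxy compounds, and how an ethoxy group or an amine in place of the hydroxy would read.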